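Clearance after trimming the sulfonyl group: compound 3

The source may report more compounds than this note shows. Statements on the series, on what has been measured and on what is new or still open speak of the compounds shown alone.

Measured in an in vitro ADME assay on microsomes from liver (Homo sapiens) for metabolic stability, read by LC-MS, tested at 1 uM; on this read-out lower numbers stand for slow clearance and higher numbers for fast clearance:
Compound 1 `Cc1ccc(S(=O)(=O)NC(C)C)cc1C#Cc1cc(Cl)ccc1OCC(=O)O`: < 10 mL.min-1.g-1
Compound 2 `Cc1ccc(S(=O)(=O)N2CCCCC2C)cc1C#Cc1cc(Cl)ccc1OCC(=O)O`: 89 mL.min-1.g-1

Compound 1 stands at < 10 mL.min-1.g-1, which is a limit of the assay and not a number. For the measured compounds named here, compound 2 gives 89 mL.min-1.g-1, the only true number in this assay so far.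

Compound 3 `Cc1ccc(S(C)(=O)=O)cc1C#Cc1cc(Cl)ccc1OCC(=O)O` has methyl in place of 2-methylpiperidin-1-yl on a sulfonyl sulfur. Going by the values given here, one measured step bears on this change: an at least 8.9-fold higher number from compound 1 to compound 2 (0.94 log units; beyond the scatter). That step brought in the same 2-methylpiperidin-1-yl, there in place of isopropylamino. Compound 3 loses this group, so a step of similar size towards lower numbers, beyond the scatter, is expected. Among the compounds with values here, no measured compound carries methyl at this place, so the expectation rests on that single step. The estimated change is a 7.4-fold lower number from compound 2 to compound 3 (0.87 log units; beyond the scatter). Compound 3 is expected at 12 mL.min-1.g-1, with an estimated range of 5 mL.min-1.g-1 to 35 mL.min-1.g-1.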

Compound 3, intrinsic clearance in microsomes: 14 mL.min-1.g-1
Compound 3: middle estimate off by 1.2-fold (0.07 log units), on the low side; measured number inside the range.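

Replacing 2-methylpiperidin-1-yl with methyl on the sulfonyl sulfur gives, in this assay, a 6.4-fold lower number from compound 2 to compound 3 (0.80 log units; beyond the scatter), so the high number of compound 2 now stands out against two smaller groups at this place, isopropylamino and methyl. The sulfonyl group thus keeps a low number in this assay with methyl as well as with isopropylamino, which do not separate on the step of an at least 1.4-fold higher number from compound 1 to compound 3 (0.14 log units; that floor lies within the scatter). The number for compound 1 is a limit of the assay and not a true number, so that comparison gives only a floor: the limit of < 10 mL.min-1.g-1 in this assay, at which 1 of the 3 values shown sits.

Going by these compounds, what piperidin-1-yl without its methyl would give at this place remains open, so the ring and its methyl cannot yet be told apart. Also open, on these data alone, is where an open-chain amine such as diethylamino or a ring such as morpholine would fall.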